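Ester to Alcohol on the Chain Carbon of Compound 3

The compounds below may be only part of what the source reports. "The series", "measured", "known", "first", "only" and "open" are said of these compounds alone.

Measured so far:
compound 1 `CCOC(=O)/C(=C\c1cccc(OCC(=O)OC(C)(C)C)c1)c1nc(-c2ccccc2)c(-c2ccccc2)o1` — > 60000 nM
compound 2 `CCOC(=O)/C(=C\c1cccc(OCC(=O)O)c1)c1nc(-c2ccccc2)c(-c2ccccc2)o1` — 360 nM
compound 3 `COC(=O)C(Cc1cccc(OCC(=O)O)c1)c1nc(-c2ccccc2)c(-c2ccccc2)o1` — 80 nM

In a functional assay for inhibition, with Homo sapiens as the target (a higher number here means a weaker inhibitor, a lower number a stronger inhibitor), compound 1 gives only a limit, > 60000 nM, and no number. Compound 2 gives 360 nM in this assay, so that an at least 160-fold lower number from compound 1 to compound 2 (2.22 log units; beyond the scatter). Compound 3 gives 80 nM in this assay, the lowest of the two numbers; compound 2 gives the higher number of the two, and that gap is beyond the scatter.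

Compound 4 `O=C(O)COc1cccc(CC(CO)c2nc(-c3ccccc3)c(-c3ccccc3)o2)c1` has not yet been measured. It differs from compound 3 in one place: hydroxymethyl in place of methoxycarbonyl on a saturated chain carbon bound to an aromatic carbon and a saturated chain carbon. Going by the values given here, the only measured step, from compound 1 to compound 2, concerns the oxygen next to the carbonyl group on the other side of the molecule, not the methoxycarbonyl that leaves here, so it does not bear directly on this change. The shift from compound 2 to compound 3 alters both the ester and the double bond, so no single-point comparison informs the step. Compound 4 is therefore expected, with wide uncertainty, to give 250 nM in this assay, between 50 nM and 1500 nM, an expected step of a 3.1-fold higher number from compound 3 to compound 4 (0.49 log units; beyond the scatter).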

Compound 4, half-maximal inhibitory concentration: 9310 nM
Compound 4: the middle estimate sits 37-fold (1.57 log units) below what was measured; measured number outside the range, above it.
By their numbers in this assay, from the lowest: compound 3; then compound 2; then compound 4. At a limit, above all of these: compound 1.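

Putting hydroxymethyl in place of methoxycarbonyl on the saturated chain carbon bound to an aromatic carbon and a saturated chain carbon gives a 120-fold higher number from compound 3 to compound 4 (2.07 log units; beyond the scatter) in this assay and so shows that the group on this carbon weighs heavily on the read-out. The free acid end shared by compound 2 and compound 3 is still present in compound 4, so that end alone does not secure a low number. Nothing measured here explains the size of this step.

The compounds shown do not separate the loss of the carbonyl from the arrival of the hydroxyl hydrogen or the shorter group. Going by these compounds, it remains open how a primary amide or an amine on this carbon would read in this assay.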